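Swapping tert-butyl for 2-phenylethenyl on a carbonyl carbon

The source may hold more compounds than are shown below. What is called first, only, known or untested is meant among the compounds shown, and "the series" means these compounds.

In an ADME assay on L6 cells (Rattus norvegicus) for cytotoxicity, with a stated time of 72 h (a lower number here means a stronger inhibitor, a higher number a weaker inhibitor), compound 1 `CN(C)C12CC(OC(=O)CN3CCCC3)C(C(c3ccccc3)C1)C(c1ccccc1)C2` gives 32700 nM, compound 2 `CCN(CC)CC(=O)OC1CC2(N(C)C)CC(c3ccccc3)C1C(c1ccccc1)C2` gives 30100 nM and compound 3 `CN(C)C12CC(OC(=O)C(C)(C)C)C(C(c3ccccc3)C1)C(c1ccccc1)C2` gives 5060 nM, the lowest of the three numbers. Compound 4 `CN(C)C12CC(OC(=O)/C=C/c3ccccc3)C(C(c3ccccc3)C1)C(c1ccccc1)C2` carries 2-phenylethenyl in place of tert-butyl on a carbonyl carbon. The nearest evidence is the arrival of tert-butyl itself: replacing (pyrrolidin-1-yl)methyl gives a 6.5-fold lower number from compound 1 to compound 3 (0.81 log units; beyond the scatter), and replacing (diethylamino)methyl gives a 5.9-fold lower number from compound 2 to compound 3 (0.77 log units; beyond the scatter). Going by the values given here, compound 4 also lacks both of those groups, but no measured compound carries 2-phenylethenyl, so no step beyond the scatter is expected. The estimated change is a 1.1-fold lower number from compound 3 to compound 4 (0.05 log units; within the scatter). For compound 4, the expected value is 4500 nM, with an estimated range of 1500 nM to 13000 nM.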

Compound 4, half-maximal inhibitory concentration: 3820 nM
Compound 4: middle estimate off by 1.2-fold (0.07 log units), on the high side; measured number inside the range.
By their numbers in this assay, from the lowest: compounds 4 and 3 (each within the scatter of the next); then compounds 2 and 1 (each within the scatter of the next).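

In this assay, 2-phenylethenyl gives a 1.3-fold lower number from compound 3 to compound 4 (0.12 log units; within the scatter), so a group carrying an aromatic ring and a double bond reads the same here as tert-butyl, within the scatter. Against the groups that carry an amine, it gives a 7.9-fold lower number from compound 2 to compound 4 (0.90 log units; beyond the scatter) and an 8.6-fold lower number from compound 1 to compound 4 (0.93 log units; beyond the scatter). All four compounds fit one pattern so far: the two without an amine in this group have the lower numbers.

Going by these compounds, what a saturated 2-phenylethyl group or a carboxylic acid would do at this position stays open. Nothing available explains these numbers.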